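The source may report more compounds than this note shows. Statements on the series, on what has been measured and on what is new or still open speak of the compounds shown alone.

Measured in a functional assay on HCT-116 cells (Homo sapiens) for inhibition, read by sulforhodamine B assay, with a stated time of 48 h, tested at 50 uM; on this read-out higher numbers stand for more inhibition of growth at the one concentration tested and lower numbers for less inhibition of growth:
- compound 1 `COc1ccc([C@@H]2CC(=O)c3cc(CC=C(C)C)c(OC)cc3O2)cc1`: 68%
- compound 2 `COc1cc2c(cc1CC=C(C)C)C(=O)C[C@@H](c1ccc(Oc3ccc(F)cc3)cc1)O2`: 29%
- compound 3 `COc1cc2c(cc1CC=C(C)C)C(=O)C[C@@H](c1ccc(Oc3cccc([N+](=O)[O-])c3)cc1)O2`: 46%

Compound 3, at 46%, holds second place among the three, with clear gaps on both sides. The record shows a number 17 percentage points higher from compound 2 to compound 3 (beyond the scatter), and also a number 22 percentage points lower from compound 1 to compound 3 (beyond the scatter).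

Compound 4 `CCCCOc1ccc([C@@H]2CC(=O)c3cc(CC=C(C)C)c(OC)cc3O2)cc1` carries butyl in place of 3-nitrophenyl on an oxygen on an aromatic ring.

Going by the values given here, the steps that bear on this change are those at the same oxygen. The large a number 39 percentage points lower from compound 1 to compound 2 (beyond the scatter) and the modest a number 22 percentage points lower from compound 1 to compound 3 (beyond the scatter) show both ring-bearing groups giving lower numbers than the methyl of compound 1. Among the compounds with values here, no measured compound has a chain longer than methyl at this place, so the reading is uncertain. Butyl has no ring, like methyl, so a modest rise in this assay is expected, with compound 4 still expected to stay lower than compound 1. Compound 1 gives 68%. The expected change is a number 11 percentage points higher from compound 3 to compound 4 (beyond the scatter).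

Compound 4 is estimated at 57%, with an expected range of 38% to 76%.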

Compound 4, percent growth inhibition at one concentration: 60%
Estimate against measurement, compound 4: 3 percentage points below; low and high end bracket the measured number.
By their numbers in this assay, from the lowest: compound 2; then compound 3; then compounds 4 and 1 (each within the scatter of the next).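

In this assay, the butyl chain on this oxygen separates clearly from both ring-bearing groups, with a number 14 percentage points higher from compound 3 to compound 4 (beyond the scatter) and a number 31 percentage points higher from compound 2 to compound 4 (beyond the scatter). The earlier compounds shown here had only methyl as a group without a ring here, and they could not show whether a longer chain would be tolerated. With a number 8 percentage points lower from compound 1 to compound 4 (within the scatter), butyl and methyl cannot be told apart on this read-out, so the two chains group together, and the 3-nitrophenyl and 4-fluorophenyl groups of compound 3 and compound 2 are the ones that stand apart.

No measurement shown here explains this difference between the chains and the ring-bearing groups. The compounds shown also leave open whether an octyl chain, a chain ending in an amine or a benzyl group at this oxygen would stay level with butyl.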